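Swapping an ester for a hydroxy on the amide-bearing ring

A few compounds are considered here, and "the series" means these few. Any claim that something is new, unique, unknown or untested is made for them only; others in the source may bear on it.

Measured so far:
- Compound 1 `C=C(CC)C(=O)c1ccc(OCC(=O)Nc2ccc3c(C)cc(=O)oc3c2)c(Cl)c1Cl`: in a functional assay on CLL cells (Homo sapiens) for cytotoxicity, read by MTT assay, with a stated time of 48 h (on this read-out lower numbers stand for an effect already at smaller amounts and higher numbers for an effect only at larger amounts of compound), compound 1 gives 2800 nM
- Compound 2 `C=C(CC)C(=O)c1ccc(OCC(=O)Nc2ccc(C(=O)OC)cc2)c(Cl)c1Cl`: in this assay compound 2 gives 4100 nM

Both compounds share the same left-hand part and differ only in the aromatic group attached to the amide nitrogen. Of the two numbers measured, compound 2 carries the higher one, though the gap to compound 1 is within the usual scatter of the measurement, so the two values cannot be told apart with confidence.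

Compound 3 `C=C(CC)C(=O)c1ccc(OCC(=O)Nc2ccc(O)cc2)c(Cl)c1Cl` has not yet been measured. It is derived from compound 2 by a single change on the six-membered aromatic ring of carbon only:

hydroxy in place of methoxycarbonyl on an aromatic carbon

Going by the values given here, no step between two measured compounds tells how such a change behaves here, so the expectation rests on the fact that both measured compounds sit close together despite a large difference in that part of the molecule. For compound 3 a step in this assay of about a 1.0-fold lower number from compound 2 to compound 3 (0.01 log units; within the scatter) is expected, which is no change beyond the scatter. The estimate for compound 3 is therefore 4000 nM, within a range of 1800 nM to 9000 nM.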

Compound 3, half-maximal effective concentration: 6400 nM
Estimate against measurement, compound 3: 1.6-fold (0.20 log units) below; low and high end bracket the measured number.
By their numbers in this assay, from the lowest: compounds 1, 2 and 3 (each within the scatter of the next, the first and the last beyond it).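

In this assay, going by these compounds alone, the swap at this place, para to a large group, gives a 1.6-fold higher number from compound 2 to compound 3 (0.19 log units; within the scatter) and is the first single change that can be read directly. Methoxycarbonyl, with 4 heavy atoms and 0 hydrogen-bond donors, leaves and hydroxy, with 1 heavy atom and 1 hydrogen-bond donor, enters, yet the step stays within the scatter, so this position tolerated a clear change in size and in donor count without a readable shift in this test. No measurement at hand bears on why the step has this size.

An amine, a carboxylic acid, a methoxy group or a longer chain such as ethoxycarbonyl at this same place could still behave differently, so the compounds shown leave open how far this tolerance extends. A single step also cannot tell whether hydroxy in place of methoxycarbonyl would behave the same way with other groups on the shared core, or whether this reading would hold in any cells other than those tested here.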